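Closing the chain into a ring on the acid carbon

This account rests on a few compounds, and the source may have more. Where it says the series, first, only, none or still open, it means among the compounds named here.

The three measured compounds share one core and differ at the branched carbon that carries the carboxylic acid. Compound 1 `CCC(CC)(CC(=O)Nc1cccc(OCc2ccc3ccc(Cl)cc3n2)c1)C(=O)O`, with two ethyl groups there and a chlorine on the bicyclic ring, gives 0.8 nM in a functional assay on ileum (Cavia porcellus) for antagonist activity at cysteinyl leukotriene receptor (Homo sapiens); a lower number here means a stronger inhibitor, a higher number a weaker inhibitor. Compound 2 `CC(C)(CC(=O)Nc1cccc(OCc2ccc3ccc(F)cc3n2)c1)C(=O)O`, with two methyl groups and a fluorine, gives 1.4 nM. Compound 3 `CCC(C)(CC(=O)Nc1cccc(OCc2ccc3ccc(F)cc3n2)c1)C(=O)O`, with one methyl and one ethyl and a fluorine, gives 6.4 nM, the highest number of the three, and the step of a 4.6-fold higher number from compound 2 to compound 3 (0.66 log units; beyond the scatter) shows that change exceeds the scatter.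

Compound 4 `O=C(CC1(C(=O)O)CCCC1)Nc1cccc(OCc2ccc3ccc(F)cc3n2)c1` has not yet been measured. It differs from compound 3 by 1-carboxycyclopentyl in place of 1-carboxy-1-methylpropyl on a saturated chain carbon bound to a carbonyl carbon, so the two open branches of compound 3 are tied together into a ring. Among the compounds with values here, no measured step maps this ring closure directly; what is known is that the step from compound 2 to compound 3 raised the number, while compound 1, carrying two ethyl groups, sits at the low end. The author therefore expects compound 4 to fall somewhere between these, and estimates a change of a 2.1-fold lower number from compound 3 to compound 4 (0.33 log units; beyond the scatter) from compound 3. For compound 4 the estimate is 3 nM, within a range from 0.8 nM to 12 nM.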

Compound 4, half-maximal inhibitory concentration: 10 nM
The estimate for compound 4 lay 3.3-fold (0.52 log units) below the measured number; the measured number falls inside the stated range.
By their numbers in this assay, from the lowest: compounds 1 and 2 (each within the scatter of the next); then compounds 3 and 4 (each within the scatter of the next).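

Tying the two open branches of 1-carboxy-1-methylpropyl into 1-carboxycyclopentyl does not separate the ring from the open form in this assay (a 1.6-fold higher number from compound 3 to compound 4 (0.19 log units; within the scatter)), so at this position the ring closure alone moves the number no further than the scatter. Measured against the smaller 1-carboxy-1-methylethyl, the ring gives a clear loss (a 7.1-fold higher number from compound 2 to compound 4 (0.85 log units; beyond the scatter)), and among the fluorine compounds both larger groups, in compound 3 and compound 4, carry higher numbers than compound 2; compound 1 appears to go against this trend with its two ethyl groups, but it also carries chlorine and so differs in more than one place. No measurement given here explains why these groups differ, and the numbers alone cannot supply a reason.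

The compounds shown leave open whether a 1-carboxycyclopropyl or 1-carboxycyclohexyl group on the same saturated chain carbon would stay level with compound 4 or come closer to compound 2. Within the data shown here, they also leave open how much of the low number of compound 1 belongs to its chlorine and how much to its two ethyl groups, since no compound pairs two ethyl groups with fluorine.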